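Varying the Group on the Shared Core

The source may hold more compounds than are shown below. What is called first, only, known or untested is meant among the compounds shown, and "the series" means these compounds.

Measured so far:
compound 1 `CCCCOC(=O)NS(=O)(=O)c1ccc(CCC)cc1-c1ccc(Cn2c(C(C)(C)C)nc3ccccc32)cc1`: 5.3 nM
compound 2 `CCCCOC(=O)NS(=O)(=O)c1ccc(CCC)cc1-c1ccc(Cn2c(C3CCCCC3)nc3ccccc32)cc1`: 130 nM
compound 3 `CCCCOC(=O)NS(=O)(=O)c1ccc(CCC)cc1-c1ccc(Cn2c(C(F)(F)F)nc3ccccc32)cc1`: 13 nM

In an assay on membranes from HEK293 cells for displacement of a labelled ligand from Type-2 angiotensin II receptor (Homo sapiens), read by radioligand binding (a lower number here means a stronger inhibitor, a higher number a weaker inhibitor), compound 3 holds the second-highest of the three numbers; its nearest neighbour is given by a 2.5-fold higher number from compound 1 to compound 3 (0.39 log units; beyond the scatter) and its furthest by a 10-fold lower number from compound 2 to compound 3 (1.00 log units; beyond the scatter). Compound 4 `CCCCOC(=O)NS(=O)(=O)c1ccc(CCC)cc1-c1ccc(Cn2c(-c3nccs3)nc3ccccc32)cc1` carries 1,3-thiazol-2-yl in place of trifluoromethyl on an aromatic carbon. Both measured steps concern this same group: a 25-fold higher number from compound 1 to compound 2 (1.39 log units; beyond the scatter) was large and a 2.5-fold higher number from compound 1 to compound 3 (0.39 log units; beyond the scatter) modest, so each change away from tert-butyl has raised the number. For the measured compounds named here, no measured step covers an aromatic ring at this place. A modest rise in this assay is expected for compound 4, a 2.3-fold higher number from compound 3 to compound 4 (0.36 log units; beyond the scatter). Compound 4 is therefore estimated at 30 nM, within 8 nM to 120 nM.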

Compound 4, inhibition constant: 5.1 nM
For compound 4 the middle estimate is 5.9-fold (0.77 log units) above the measured one, and the stated range ends above it.
By their numbers in this assay, from the lowest: compounds 4 and 1 (each within the scatter of the next); then compound 3; then compound 2.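

In this assay, for the compounds shown here, 1,3-thiazol-2-yl brings an aromatic ring to this place for the first time, and the number falls both with a 2.5-fold lower number from compound 3 to compound 4 (0.41 log units; beyond the scatter) and with a 25-fold lower number from compound 2 to compound 4 (1.41 log units; beyond the scatter). Against tert-butyl there is no separation, with a 1.0-fold lower number from compound 1 to compound 4 (0.02 log units; within the scatter), so tert-butyl is no longer alone at the low end of the series and a change away from it need not raise the number. Nothing measured here accounts for this result.

From the compounds shown here alone, whether this level needs the ring nitrogen and sulfur of 1,3-thiazol-2-yl or only an aromatic ring remains open; a plain phenyl ring at this place would separate the two.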